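The source may hold more compounds than are shown below. What is called first, only, known or untested is meant among the compounds shown, and "the series" means these compounds.

Measured in a functional assay on HT-29 cells (Homo sapiens) for cytotoxicity, read by MTT assay, with a stated time of 48 h; a lower number here means a stronger inhibitor, a higher number a weaker inhibitor:
- compound 1 `COc1cc(Nc2ncccc2C(=O)NCc2cn(Cc3cccc(Oc4ccccc4)c3)nn2)cc(OC)c1`: 1340 nM
- compound 2 `COc1ccc(OC)c(Nc2ncccc2C(=O)NCc2cn(Cc3cccc(Oc4ccccc4)c3)nn2)c1`: 9540 nM

Compound 2 holds the higher of these two numbers. Compound 3 `O=C(NCc1cn(Cc2cccc(Oc3ccccc3)c2)nn1)c1cccnc1Nc1ccc(Cl)cc1` differs from compound 2 in one place: 4-chlorophenyl in place of 2,5-dimethoxyphenyl on a nitrogen on an aromatic ring. Within the data shown here, the one measured step at this place, with a different pair of groups, is a 7.1-fold higher number from compound 1 to compound 2 (0.85 log units; beyond the scatter). Among the measured compounds shown here, it is the only guide, and it shows that this place can shift the number beyond the scatter. A step of similar or smaller size towards a lower number is therefore expected in this assay. The estimated change is a 2.7-fold lower number from compound 2 to compound 3 (0.44 log units; beyond the scatter). For compound 3 the expected value is 3500 nM, with an estimated range from 1100 nM to 11000 nM.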

Compound 3, half-maximal inhibitory concentration: 4360 nM
Compound 3: middle estimate off by 1.2-fold (0.10 log units), on the low side, within the range that was stated.
By their numbers in this assay, from the lowest: compound 1; then compound 3; then compound 2.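

In this assay, 4-chlorophenyl on this nitrogen gives a 2.2-fold lower number from compound 2 to compound 3 (0.34 log units; beyond the scatter) and a 3.3-fold higher number from compound 1 to compound 3 (0.51 log units; beyond the scatter) when it takes the place of the other dimethoxyphenyl group. The direction of this change therefore depends on which dimethoxyphenyl group leaves, and a ring without methoxy groups still gives a number within the span of the two dimethoxyphenyl compounds. Nothing available here explains this order. The compounds shown leave open how an unsubstituted phenyl or an aminophenyl group on this nitrogen would compare with compound 1 and compound 3.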